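Methyl in place of methoxy on compound 3

The source may hold more compounds than are shown below. What is called first, only, known or untested is meant among the compounds shown, and "the series" means these compounds.

In a functional assay on A549 cells (Homo sapiens) for antiproliferative activity, read by MTT assay, with a stated time of 72 h (on this read-out higher numbers stand for weaker inhibition and lower numbers for stronger inhibition), compound 1 `O=C1COc2ccc(-c3cccc(NS(=O)(=O)c4ccc(F)cc4)c3)cc2N1` gives 32100 nM, and compound 3 `COc1ccc(N2C(=O)COc3ccc(-c4cccc(NS(=O)(=O)c5ccc(F)cc5)c4)cc32)cc1` gives 38200 nM. In this assay compound 2 `O=C1COc2ccc(-c3cccc(NS(=O)(=O)c4ccc(F)cc4)c3)cc2N1C1CC1` gives only a limit, > 40000 nM, and no number. The numbers place compound 3 level with compound 1, with a gap of a 1.2-fold higher number from compound 1 to compound 3 (0.08 log units; within the scatter). Compound 4 `Cc1ccc(N2C(=O)COc3ccc(-c4cccc(NS(=O)(=O)c5ccc(F)cc5)c4)cc32)cc1` differs from compound 3 by methyl in place of methoxy on an aromatic carbon, para to a large group. Going by the values given here, no measured step tests this change directly. The nearest steps replace the group on the amide-type nitrogen, giving a 1.2-fold higher number from compound 1 to compound 3 (0.08 log units; within the scatter) and an at least 1.0-fold lower number from compound 2 to compound 3 (0.01 log units; that floor lies within the scatter). From these small steps, the expected change is none beyond the scatter, an estimated 1.1-fold lower number from compound 3 to compound 4 (0.04 log units; within the scatter). For compound 4 the estimate is 35000 nM, with an expected range from 18000 nM to 50000 nM.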

Compound 4, half-maximal inhibitory concentration: > 40000 nM
Compound 4: no number, only a limit (the forecaster's own chance of this, stated with the estimate: 35%); middle value at least 1.1-fold (0.05 log units) away from the limit.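

In this assay, methyl in place of methoxy on this aromatic carbon gives an at least 1.0-fold higher number from compound 3 to compound 4 (0.01 log units; that floor lies within the scatter), so the change shows no sign of stronger inhibition at this position. The 4-methylphenyl group in place of hydrogen on the amide-type nitrogen gives an at least 1.2-fold higher number from compound 1 to compound 4 (0.09 log units; that floor lies within the scatter), and neither floor rules out a larger step. The step between compound 2 and compound 4 cannot be read because both are limits: the limit of > 40000 nM in this assay, at which 2 of the 4 values shown sit.

From the compounds shown here alone, how far compound 2 and compound 4 lie beyond that limit stays open. So does whether an amine or a carboxylic acid at this position would lower the number.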